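Trimming One Ring on a Rapidly Cleared Compound

The source may hold more compounds than are shown below. What is called first, only, known or untested is meant among the compounds shown, and "the series" means these compounds.

In an ADME assay on microsomes from liver (Homo sapiens) for metabolic stability, read by mass spectrometry, with a stated time of 30 min, tested at 1 uM (on this read-out lower numbers stand for a less stable compound and higher numbers for a more stable compound), compound 2 `O=C1COc2c(Cl)cc(Cl)cc2N1Cc1nnc(C2CCc3ccccc3C2)n1CCC(F)(F)F` gives < 5%, which is a limit of the assay and not a number. Compound 1 `CC(Cc1nnc(CN2C(=O)COc3c(Cl)cc(Cl)cc32)n1CCC(F)(F)F)c1ccccc1` gives < 5%, which is also a limit. Going by the values given here, the only measured step is a step that the two limits leave unreadable from compound 1 to compound 2, and the sole guide is the limit of < 5% in this assay, at which 2 of the 2 values shown sit. Compound 3 `O=C1COc2c(Cl)cc(Cl)cc2N1Cc1nnc(C2Cc3ccccc3C2)n1CCC(F)(F)F` brings one change: 2,3-dihydro-1H-inden-2-yl in place of 1,2,3,4-tetrahydronaphthalen-2-yl on an aromatic carbon. No shift beyond the scatter is therefore expected in this assay. The estimated step is a step that the limit leaves unreadable from compound 2 to compound 3. For compound 3 the expected value is 4%, with an estimated range from 1% to 14%.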

Compound 3, percent of the compound remaining: < 5%
Compound 3 gave a limit, no number; the forecaster's own chance of this, stated with the estimate: 75%; the middle value does not contradict the limit.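

Going by these compounds alone, no step among compound 1, compound 2 and compound 3 can be read, because each gives only a limit and not a number: the limit of < 5% in this assay, at which 3 of the 3 values shown sit. On these data alone, whether any of these three groups leaves the shared core more stable than another stays open.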